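Benzyloxy in Place of Nitro at a Limit Value

The source may hold more compounds than are shown below. What is called first, only, known or untested is meant among the compounds shown, and "the series" means these compounds.

Compound 2 `O=C(O)c1cnc(-c2ccccc2[N+](=O)[O-])[nH]c1=O` carries a nitro on an aromatic carbon of the shared core. In a functional assay on the whole organism (strain Sprague-Dawley) for inhibition, with Rattus norvegicus as the target, with a stated time of 10 min (a higher number here means that more compound is needed for the effect, a lower number that less compound is needed), compound 2 gives only a limit, > 50 mg/kg, and no number. Compound 1 `O=C(O)c1cnc(-c2ccccc2Cl)[nH]c1=O`, the chloro analogue, gives 5 mg/kg in this assay. Compound 3 `O=C(O)c1cnc(-c2ccccc2O)[nH]c1=O`, the hydroxy analogue, gives in this assay only a limit, > 5 mg/kg. For the measured compounds named here, the one readable step is an at least 10-fold higher number from compound 1 to compound 2 (1.00 log units; beyond the scatter). The steps of a number no lower from compound 1 to compound 3 (the limit leaves the size open) and a step that the two limits leave unreadable from compound 2 to compound 3 are left open by the two limits, the limit of > 5 mg/kg in this assay, at which 1 of the 3 values shown sits, and (the limit of > 50 mg/kg in this assay, at which 1 of the 3 values shown sits).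

Compound 4 `O=C(O)c1cnc(-c2ccccc2OCc2ccccc2)[nH]c1=O` differs from compound 2 by benzyloxy in place of nitro on an aromatic carbon. Going by the values given here, no measured step touches a benzyloxy, and compound 2 itself stands only at a limit, so the size of the change is open in both directions. The step of an at least 3.3-fold lower number from compound 2 to compound 4 (0.52 log units; beyond the scatter) is therefore an estimate that compound 4 returns to a measurable number, with wide bounds. Compound 4 is expected to give 15 mg/kg in this assay, within 4 mg/kg to 50 mg/kg.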

Compound 4, dose for 50% inhibition: 5 mg/kg
Compound 4: the middle estimate sits 3.0-fold (0.48 log units) above what was measured; the range from low to high includes it.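

For the compounds shown here, until this result, chloro was the only group on this aromatic carbon to give a number in this assay, and benzyloxy, with its 8 heavy atoms and its own aromatic ring, now gives a second one, with no change at the digits printed from compound 1 to compound 4 (within the scatter). Chloro and benzyloxy therefore cannot be told apart in this assay. Set against nitro, the change is an at least 10-fold lower number from compound 2 to compound 4 (1.00 log units; beyond the scatter). Compound 3 gives only a limit, > 5 mg/kg. The step that places benzyl on its oxygen is a number no higher from compound 3 to compound 4 (the limit leaves the size open), so its size cannot be read.

Going by these compounds, what separates nitro from chloro and benzyloxy stays open. The compounds shown also leave open whether an amine or a longer alkoxy chain on this aromatic carbon would give a number in the same range.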